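Adding a Chloro Group to a Compound at the Assay Limit

This account rests on a few compounds, and the source may have more. Where it says the series, first, only, none or still open, it means among the compounds named here.

Compound 1 `COc1ccc(N(C)c2ncnc3c2ncn3Cc2ccc(OC)c(OC)c2)cc1`: > 100000 nM
Compound 2 `COc1ccc(N(C)c2ncnc3c2ncn3Cc2cc(OC)c(OC)c(OC)c2)cc1`: > 100000 nM

In a functional assay on AGS cells (Homo sapiens) for antiproliferative activity, read by MTT assay, with a stated time of 48 h (a higher number here means a weaker inhibitor of growth, a lower number a stronger inhibitor of growth), compound 2 gives > 100000 nM. This is a limit of the assay and not a number. Compound 2 thus stands at the limit of > 100000 nM in this assay, at which 2 of the 2 values shown sit.

Compound 3 `COc1ccc(N(C)c2nc(Cl)nc3c2ncn3Cc2cc(OC)c(OC)c(OC)c2)cc1` differs from compound 2 by one change: chloro in place of hydrogen on an aromatic carbon. A chloro replaces hydrogen on an aromatic carbon, between two ring nitrogen atoms.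

Among the compounds with values here, the only measured step is a step that the two limits leave unreadable from compound 1 to compound 2. It is a different change, methoxy in place of hydrogen, and gives no size to carry over. With so little to go on, only a cautious guess is possible: a modest move towards stronger growth inhibition in this assay, though the assay may again report only a limit.

The expected change is an at least 3.3-fold lower number from compound 2 to compound 3 (0.52 log units; beyond the scatter).

Compound 3 is estimated at 30000 nM, with an expected range of 3000 nM to 100000 nM.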

Compound 3, concentration for 50% growth inhibition: 85000 nM
For compound 3 the middle estimate is 2.8-fold (0.45 log units) below the measured one; measured number inside the range.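

In this assay, the chloro group between two ring nitrogen atoms yields the only readable number among the compounds shown: compound 3 gives 85000 nM. The change amounts to an at least 1.1-fold lower number from compound 2 to compound 3 (0.07 log units; that floor lies within the scatter), so it is bounded from one side only and does not by itself establish a real gain in growth inhibition. Its true size stays unknown because compound 2 gives only a limit of the assay, not a number: the limit of > 100000 nM in this assay, at which 2 of the 3 values shown sit.

The step from compound 1 to compound 2 cannot be read, which leaves the effect of the added methoxy open. Also open, from the compounds shown here alone, is whether an amine or a bromo group in place of the chloro would give a lower number, and whether the chloro would give a readable value on the core of compound 1.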